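The compounds below may be only part of what the source reports. "The series", "measured", "known", "first", "only" and "open" are said of these compounds alone.

Compound 1, `O=C(CN1CCN(C(=O)c2ccccc2)CC1)N1CCN(CCCc2c[nH]c3ccccc23)CC1`, measured in an ADME assay on HEK293 cells (Homo sapiens) for cytotoxicity, read by MTT assay, with a stated time of 72 h (a higher number here means a weaker inhibitor, a lower number a stronger inhibitor), gives > 200000 nM, which is a limit of the assay and not a number.
Compound 2, `O=C(CN1CCN(C(=O)c2ccc(F)cc2)CC1)N1CCN(CCCc2c[nH]c3ccccc23)CC1`, measured in this assay, gives 141000 nM.

For the measured compounds named here, compound 2 is the only compound with a proper number in this assay; the one other value shown is a limit. Going by the values given here, the single measured step, an at least 1.4-fold lower number from compound 1 to compound 2 (0.15 log units; that floor lies within the scatter), starts from that limit, as the evidence the limit of > 200000 nM in this assay, at which 1 of the 2 values shown sits, records, so its true size is not known beyond its floor.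

Compound 3, `O=C(CN1CCN(C(=O)c2cccc(F)c2)CC1)N1CCN(CCCc2c[nH]c3ccccc23)CC1`, differs from compound 2 by 3-fluorophenyl in place of 4-fluorophenyl on a carbonyl carbon. Among the compounds with values here, no measured step moves a fluorine from one position of the ring to another; the step from compound 1 to compound 2 only added a fluorine, and its size was at most modest. With nothing in the data pointing to a change in either direction, the expectation is no step beyond the scatter, so the estimated step of no change at the digits printed from compound 2 to compound 3 (within the scatter) is taken as flat. Compound 3 is therefore estimated at 141000 nM in this assay, with a range from 70000 nM to 280000 nM.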

Compound 3, half-maximal inhibitory concentration: 182000 nM
The estimate for compound 3 lay 1.3-fold (0.11 log units) below the measured number; the range from low to high includes it.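

Moving the fluorine, with 3-fluorophenyl in place of 4-fluorophenyl on the carbonyl carbon, gives a 1.3-fold higher number from compound 2 to compound 3 (0.11 log units; within the scatter) in this assay. For the compounds shown here, this is the first direct comparison of two fluorine placements on this ring, and the difference between them cannot be told apart from the ordinary scatter of repeated measurements. Adding a fluorine at the other ring position gives a second fluoro-for-hydrogen step, an at least 1.0-fold lower number from compound 1 to compound 3 (0.04 log units; that floor lies within the scatter), and its size stays unknown beyond that floor because compound 1 has a limit and not a number: the limit of > 200000 nM in this assay, at which 1 of the 3 values shown sits.

The compounds shown leave open whether a different group on the phenyl ring attached to this carbonyl carbon, such as a chlorine, a methoxy group or an amine, would move the number beyond the scatter. On these data alone, how far compound 2 and compound 3 truly lie from compound 1 also stays open, and so does whether any fluorine on this ring makes a real difference to the reading at all.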